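The source may hold more compounds than are shown below. What is called first, only, known or untested is meant among the compounds shown, and "the series" means these compounds.

Among the measured compounds shown here, compound 3 `CC(C)(Oc1ccc(F)cc1[N+](=O)[O-])C1OCC(C/C=C\CCC(=O)O)C(c2cccnc2)O1` stands lowest of the three numbers so far in an assay for inhibition of Thromboxane-A synthase (Homo sapiens), using microsomes (on this read-out higher numbers stand for weaker inhibition and lower numbers for stronger inhibition), giving 20 nM. Compound 1 `CC(C)(Oc1ccc(F)cc1)C1OCC(C/C=C\CCC(=O)O)C(c2cccnc2)O1` gives 51 nM in this assay, and compound 2 `COc1ccccc1OC(C)(C)C1OCC(C/C=C\CCC(=O)O)C(c2cccnc2)O1` gives 60 nM. The step of a 2.6-fold lower number from compound 1 to compound 3 (0.41 log units; beyond the scatter) and the step of a 3.0-fold lower number from compound 2 to compound 3 (0.48 log units; beyond the scatter) set compound 3 apart from both, whereas the step of a 1.2-fold higher number from compound 1 to compound 2 (0.07 log units; within the scatter) does not separate compounds 1 and 2 from each other.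

Compound 4 `CC(C)(Cc1ccc(F)cc1C#N)C1OCC(C/C=C\CCC(=O)O)C(c2cccnc2)O1` has not been measured. It differs from compound 3 in a group of 10 heavy atoms (8 carbon, 1 nitrogen, 1 fluorine; one six-membered aromatic ring of carbon only) in place of a group of 11 heavy atoms (6 carbon, 1 nitrogen, 3 oxygen, 1 fluorine; one six-membered aromatic ring of carbon only), on a saturated chain carbon bound to two saturated chain carbons and a saturated ring carbon. The leaving group carries three oxygens and a double bond outside its ring; the entering group carries no oxygen but a triple bond, a nitrile in place of the nitro group, and it is joined to the shared core through carbon rather than oxygen. For the measured compounds named here, none of the measured steps makes such a swap, so none bears on it directly. What the three steps do show is that changing the ring attached at this place, or its substituents, moves this assay only within the scatter or by modest amounts. A modest step is therefore expected here too, most likely toward a somewhat higher number, since the nitro group that helped compound 3 is gone. Compound 4 is estimated at 40 nM, with a likely range from 12 nM to 130 nM, meaning an expected step of a 2.0-fold higher number from compound 3 to compound 4 (0.30 log units; within the scatter).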

Compound 4, half-maximal inhibitory concentration: < 10 nM
Compound 4 ended at the assay's limit; the forecaster's own chance of this, stated with the estimate: 2%; middle value at least 4.0-fold (0.60 log units) from the limit.
By their numbers in this assay, from the lowest: compound 3; then compounds 1 and 2 (each within the scatter of the next). At a limit, below all of these: compound 4.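

The ring on this saturated chain carbon can be joined through carbon rather than oxygen, with a nitrile in place of the nitro group, and inhibition does not weaken in this assay. This group, which carries no oxygen, gives stronger inhibition than the oxygen-linked groups of the two weaker compounds, with steps beyond the scatter: an at least 6.0-fold lower number from compound 2 to compound 4 (0.77 log units; beyond the scatter) and an at least 5.1-fold lower number from compound 1 to compound 4 (0.70 log units; beyond the scatter). Against the nitro compound the picture is less firm, since the floor of an at least 2.0-fold lower number from compound 3 to compound 4 (0.30 log units; that floor lies within the scatter) lies within the scatter and the two compounds cannot yet be told apart, and compound 4 itself stands at a limit of the assay and not at a number: the limit of < 10 nM in this assay, at which 1 of the 4 values shown sits.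

The change swaps the link and the ring substituent together, so these compounds cannot show which of the two carries the step, nor how far under its limit compound 4 really lies. From the compounds shown here alone, how an amine or a carboxylic acid in place of the nitrile, or a longer chain in place of the single carbon link, would read in this assay also stays open.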